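A methoxy on the isopropoxy chain of compound 1

The source may report more compounds than this note shows. Statements on the series, on what has been measured and on what is new or still open speak of the compounds shown alone.

Compound 1 `CC(C)Oc1cc(Oc2cnc(C(=O)N(C)C)nc2)cc(-c2nccc(=O)[nH]2)c1` with < 8 mL/min/kg (a limit)
Compound 2 `COc1cnc(-c2cc(Oc3ccc(S(C)(=O)=O)cc3)cc(OC(C)C)c2)[nH]c1=O` with < 8 mL/min/kg (a limit)

In an ADME assay on microsomes from liver (Homo sapiens) for metabolic stability (a higher number here means faster removal of the compound, a lower number slower removal), compound 1 gives < 8 mL/min/kg and this is a limit of the assay, not a number. Compound 1 therefore stands at the limit of < 8 mL/min/kg in this assay, at which 2 of the 2 values shown sit, and has no exact value. Compound 3 `COC[C@H](C)Oc1cc(Oc2cnc(C(=O)N(C)C)nc2)cc(-c2nccc(=O)[nH]2)c1` differs from compound 1 by methoxy in place of hydrogen on a saturated chain carbon, two bonds along the chain from an oxygen on an aromatic ring and carries methoxy in place of hydrogen on a saturated chain carbon, so isopropoxy becomes 1-(methoxymethyl)ethoxy. Among the compounds with values here, no measured pair shows this change. The expected step of an at least 1.1-fold higher number from compound 1 to compound 3 (0.05 log units; that floor lies within the scatter) is small, towards faster removal, and may stay within the scatter. The estimated clearance of compound 3 is 9 mL/min/kg with 6 mL/min/kg to 16 mL/min/kg as its expected range.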

Compound 3, clearance: < 8 mL/min/kg
Compound 3: only a limit was reported; the forecaster's own chance of this, stated with the estimate: 55%; middle value at least 1.1-fold (0.05 log units) away from the limit.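

In this assay compound 3 gives < 8 mL/min/kg, a limit of the assay. Within the data shown here, compound 1 also stands at a limit, so no step between compound 1 and compound 3 can be read. The compounds shown leave open whether the methoxy changes clearance at all, with every value at one point: the limit of < 8 mL/min/kg in this assay, at which 3 of the 3 values shown sit.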